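Compound 3 to compound 4: replacing the morpholine amide

The compounds below may be only part of what the source reports. "The series", "measured", "known", "first", "only" and "open" are said of these compounds alone.

Values in a physicochemical assay for solubility, read by spectrophotometry; a lower number here means a less soluble compound, a higher number a more soluble compound:
compound 1 `CCN(CC)C(=O)COc1ccc(-c2cc(=O)c3c(O)c(O)c(O)cc3o2)cc1`: 8.95 ug/mL
compound 2 `CC(C)N(C(=O)Oc1ccc(-c2cc(=O)c3c(O)c(O)c(O)cc3o2)cc1)C(C)C`: 8.67 ug/mL
compound 3 `O=C(COc1ccc(-c2cc(=O)c3c(O)c(O)c(O)cc3o2)cc1)N1CCOCC1`: 9.45 ug/mL

Compound 3 at 9.45 ug/mL cannot be separated from the other two measured compounds: the steps are a 1.1-fold higher number from compound 1 to compound 3 (0.02 log units; within the scatter) and a 1.1-fold higher number from compound 2 to compound 3 (0.04 log units; within the scatter).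

Next in the series is compound 4 `CN(C)CCCOc1ccc(-c2cc(=O)c3c(O)c(O)c(O)cc3o2)cc1`, which differs from compound 3 as follows: 2-(dimethylamino)ethyl in place of (morpholin-4-yl)carbonyl on a saturated chain carbon bound to an oxygen on an aromatic ring. The same difference, cut one bond further out, reads ((morpholin-4-yl)carbonyl)methyl to 3-(dimethylamino)propyl.

Within the data shown here, three measured steps bear on this change. One places morpholin-4-yl in place of diethylamino on a carbonyl carbon, a 1.1-fold higher number from compound 1 to compound 3 (0.02 log units; within the scatter). The other two exchange the whole group on the oxygen on an aromatic ring, a 1.0-fold lower number from compound 1 to compound 2 (0.01 log units; within the scatter) and a 1.1-fold higher number from compound 2 to compound 3 (0.04 log units; within the scatter). All three lie within the scatter, but every measured compound keeps a carbonyl in this group, and none carries 3-(dimethylamino)propyl. How far these steps carry over to compound 4 is therefore uncertain.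

The estimated step is a 1.5-fold higher number from compound 3 to compound 4 (0.17 log units; within the scatter), which is not expected to exceed the scatter, although the range is left wider on the high side for this untested change. For compound 4 the expected value is 14 ug/mL, with an estimated range of 6 ug/mL to 50 ug/mL.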

Compound 4, solubility: 8.5 ug/mL
For compound 4 the middle estimate is 1.6-fold (0.22 log units) above the measured one; measured number inside the range.
By their numbers in this assay, from the lowest: compounds 4, 2, 1 and 3 (each within the scatter of the next).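

In this assay, the position on the saturated chain carbon bound to an oxygen on an aromatic ring now accepts a group without a carbonyl, and the read-out still cannot be separated from the amide and carbamate compounds: the steps are a 1.1-fold lower number from compound 3 to compound 4 (0.05 log units; within the scatter) and a 1.0-fold lower number from compound 2 to compound 4 (0.01 log units; within the scatter) and a 1.1-fold lower number from compound 1 to compound 4 (0.02 log units; within the scatter) in that order. Compound 4 extends the earlier result, which covered only carbonyl-bearing groups, to a change that removes both the carbonyl and the six-membered non-aromatic ring and leaves 3-(dimethylamino)propyl on the oxygen, so all four groups now fall within the scatter of one another. No supporting measurement bears on why these values stay together.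

The compounds shown leave open whether this insensitivity extends to a carboxylic acid, a piperazine or a longer chain ending in an amine on the same oxygen, any of which could still separate from the present group of values. They also leave open whether the shared core sets the read-out, a question that a compound with methoxy in place of its hydroxy groups would address.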